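The compounds below may be only part of what the source reports. "The series", "measured", "known", "first", "only" and "open" are said of these compounds alone.

Measured in a physicochemical assay for lipophilicity; a higher number here means a more lipophilic compound, a lower number a more polar compound:
- compound 1 `O=C(CN(C(=O)c1ccc(-c2ccccn2)cc1)C1CCOCC1)Nc1cc(F)cc(F)c1`: 2.5
- compound 2 `CCC(COC)N(CC(=O)Nc1cc(F)cc(F)c1)C(=O)c1ccc(-c2ccccn2)cc1`: 3.3

Compound 2 is the higher of the two at 3.3. Next is compound 3 `O=C(CN(C(=O)c1ccc(-c2ccccn2)cc1)C1CCOC1)Nc1cc(F)cc(F)c1`, with oxolan-3-yl in place of 1-(methoxymethyl)propyl on an amide-type nitrogen. Among the compounds with values here, the only measured step bearing on this is a number 0.80 log units higher from compound 1 to compound 2 (beyond the scatter), a modest change beyond the scatter, in which the same chain replaced oxan-4-yl. Here a ring replaces that chain, so a fall of similar size in this assay is expected, though no measurement covers oxolan-3-yl itself. The expected step is a number 1.00 log units lower from compound 2 to compound 3 (beyond the scatter). The estimate for compound 3 is 2.3, with an expected range of 1.9 to 2.7.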

Compound 3, distribution coefficient: 2.5
Compound 3: middle estimate off by 0.20 log units, on the low side; measured number inside the range.
By their numbers in this assay, from the lowest: compounds 1 and 3 (each within the scatter of the next); then compound 2.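

In this assay, oxolan-3-yl in place of 1-(methoxymethyl)propyl on the amide-type nitrogen gives a number 0.80 log units lower from compound 2 to compound 3 (beyond the scatter), so this open chain stands apart from a second ring as well as from oxan-4-yl. Exchanging the two rings gives no change at the digits printed from compound 1 to compound 3 (within the scatter), so ring size does not separate these two cyclic ethers at this position. Nothing available explains the gap between the rings and the chain.

As far as these compounds go, whether the ring itself or its oxygen goes with the lower number remains open. A cyclopentyl group, a piperidinyl amine or a longer ether chain on the same nitrogen would test how far this holds.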